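Silyl-to-acetyl exchange on a diterpenoid lactone scaffold

The source may hold more compounds than are shown below. What is called first, only, known or untested is meant among the compounds shown, and "the series" means these compounds.

Three compounds sharing one core have been examined in a functional assay on Lu1 cells (Homo sapiens) for cytotoxicity, read by sulforhodamine B assay; on this read-out higher numbers stand for an effect only at larger amounts of compound and lower numbers for an effect already at smaller amounts. Compound 1, `C=C1CC[C@@H]2[C@](C)(COC(C)=O)[C@H](OC(C)=O)CC[C@@]2(C)[C@@H]1C/C=C1/C(=O)OC[C@H]1OC(C)=O`, gives 12.4 uM. Compound 2, `C=C1CC[C@@H]2[C@](C)(CO[Si](C(C)C)(C(C)C)C(C)C)[C@H](OC(C)=O)CC[C@@]2(C)[C@@H]1C/C=C1/C(=O)OC[C@H]1OC(C)=O`, gives 18.8 uM. Compound 3, `C=C1CC[C@@H]2[C@](C)(CO[Si](C(C)C)(C(C)C)C(C)C)[C@H](O)CC[C@@]2(C)[C@@H]1C/C=C1/C(=O)OC[C@H]1O`, gives 3.01 uM, the lowest of the three numbers, and its gaps to compound 1 and compound 2 are both beyond the scatter. The change from compound 2 to compound 1 is a group of 3 heavy atoms (2 carbon, 1 oxygen; no ring) in place of a group of 10 heavy atoms (9 carbon, 1 silicon; no ring), on an oxygen on a saturated carbon, and it made a 1.5-fold lower number from compound 2 to compound 1 (0.18 log units; within the scatter). How the core of compound 3 differs from that of compound 2 is not broken down here.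

Compound 4, `C=C1CC[C@@H]2[C@](C)(COC(C)=O)[C@H](O)CC[C@@]2(C)[C@@H]1C/C=C1/C(=O)OC[C@H]1O`, has not yet been measured in this assay. For the measured compounds named here, it differs from compound 3 by a group of 3 heavy atoms (2 carbon, 1 oxygen; no ring) in place of a group of 10 heavy atoms (9 carbon, 1 silicon; no ring), on an oxygen on a saturated carbon, the same change, at the same kind of place, as the one from compound 2 to compound 1. Because that earlier step was a 1.5-fold lower number from compound 2 to compound 1 (0.18 log units; within the scatter), a step of similar size, within the scatter, is expected from compound 3 to compound 4, namely a 1.4-fold lower number from compound 3 to compound 4 (0.14 log units; within the scatter). Compound 4 is therefore estimated at 2.2 uM, with a likely range from 1 uM to 5 uM.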

Compound 4, concentration for half-maximal effect: 14 uM
The estimate for compound 4 lay 6.4-fold (0.80 log units) below the measured number; the measured number lies above the stated range.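

In this assay, putting acetyl in place of the group of 10 heavy atoms (9 carbon, 1 silicon), on an oxygen on a saturated carbon, gave a 4.7-fold higher number from compound 3 to compound 4 (0.67 log units; beyond the scatter). For the compounds shown here, the change therefore did not carry over from one core to the other with the same outcome, so a step read on one of these cores cannot be assumed to hold on the other: the same change on two cores in this assay, a 1.5-fold lower number (0.18 log units; within the scatter) from compound 2 to compound 1 and a 4.7-fold higher number (0.67 log units; beyond the scatter) from compound 3 to compound 4, 7.1-fold (0.85 log units) apart, beyond the scatter of two such steps With only one pair on each core, this does not show which feature of the cores sets the two steps apart, nor how the same change would run on a third core.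

The compounds shown leave open whether a free hydroxyl, a methyl ether or a longer acyl chain on that oxygen would also give different steps on the two cores. They also leave open whether the difference between the cores would appear on any read-out other than this assay.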